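A few compounds are considered here, and "the series" means these few. Any claim that something is new, unique, unknown or untested is made for them only; others in the source may bear on it.

The measured compounds:

compound 1, `CCCc1nn(C)c2c(NCc3ccc(F)cc3)nc(CCc3cccnc3)nc12`, in a functional assay on L02 cells (Homo sapiens) for inhibition, read by Griess assay, with stated times of 1 h and 24 h (a lower number here means a stronger inhibitor, a higher number a weaker inhibitor), gives < 40000 nM, a limit of the assay
compound 2, `C(=C/c1ccco1)\c1nc(NC2CC2)c2sccc2n1`, in this assay gives > 1000000 nM, a limit of the assay
compound 3, `COc1cc(/C=C/c2nc(NC3CC3)c3sccc3n2)cc(OC)c1OC`, in this assay gives > 1000000 nM, a limit of the assay

Compound 3 stands at the limit of > 1000000 nM in this assay, at which 2 of the 3 values shown sit, and the same is true of compound 2, which shares its core with compound 3. Among the measured compounds shown here, compound 1 is the only one whose value sits at the limit of < 40000 nM in this assay, at which 1 of the 3 values shown sits, and it carries a different core. No pair of these compounds differs in a single place, so no measured step can be drawn from them.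

Compound 4, `COc1cc(/C=C/c2nc(NCc3ccncc3)c3sccc3n2)cc(OC)c1OC`, is the unmeasured partner of compound 3. The change is (pyridin-4-yl)methyl in place of cyclopropyl on a nitrogen on an aromatic ring. With the whole series of compound 2 and compound 3 on the shared core standing at a limit, the step from compound 3 to compound 4 is expected to be an at least 1.6-fold lower number from compound 3 to compound 4 (0.22 log units; that floor lies within the scatter), likely no larger than the scatter, and the value for compound 4 in this assay is expected to be 600000 nM, between 100000 nM and 3000000 nM, with a good chance of being reported only as a limit.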

Compound 4, half-maximal inhibitory concentration: 374000 nM
Beside the measured number, compound 4's estimate is 1.6-fold (0.21 log units) above it; the range from low to high includes it.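

In this assay, among the compounds shown here, compound 4 gives 374000 nM, the only value on the shared core that is not a limit of the assay. For the compounds shown here, putting (pyridin-4-yl)methyl in place of cyclopropyl on a nitrogen on an aromatic ring produces an at least 2.6-fold lower number from compound 3 to compound 4 (0.42 log units; beyond the scatter), so the group at this position can move the read-out on this core, which the earlier compounds could not show. The true size of the step stays unknown because compound 3 holds only a limit of the assay: the limit of > 1000000 nM in this assay, at which 2 of the 4 values shown sit.

The compounds shown leave open whether the ring nitrogen of (pyridin-4-yl)methyl matters or only the larger group, and a benzyl group on the same nitrogen would separate the two. On these data alone, whether the same change would act alike on compound 2 also remains open.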